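The compounds below may be only part of what the source reports. "The series", "measured", "known", "first", "only" and "open" are said of these compounds alone.

Compound 1 `COc1ccc2ncc(S(=O)(=O)c3cccc(C#N)c3)c(N3CCC(C)CC3)c2c1` was tested in an assay on isolated protein for displacement of a labelled ligand from metabotropic glutamate receptor 5 (Homo sapiens), with a stated time of 60 min, tested at 1 uM (a lower number here means less inhibition, a higher number more inhibition at the concentration tested (going by the name of the read-out)), where compound 1 gives 90%. Among the measured compounds shown here, its only measured companion is compound 2 `CC1CCN(c2c(S(=O)(=O)c3cccc(C#N)c3)cnc3ccc(F)cc23)CC1`, which in this assay gives 93%. For the measured compounds named here, the two numbers sit within the scatter of each other, so compound 1 cannot be set apart from compound 2 on this evidence; the one recorded step, a number 3 percentage points higher from compound 1 to compound 2 (within the scatter), concerns a fluoro in place of a methoxy on the shared core and falls inside the usual scatter.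

Compound 3 `COc1ccc2ncc(S(=O)(=O)c3cccc(F)c3)c(N3CCC(C)CC3)c2c1` has not been measured. Compared with compound 1, the change is fluoro in place of cyano on an aromatic carbon. Going by the values given here, no measured step touches this part of the molecule, so there is nothing to show how a fluoro in place of a cyano behaves here; the only guide is that the one exchange recorded on the core, from compound 1 to compound 2, left the number essentially unchanged. The step expected from compound 1 to compound 3 is therefore a number 6 percentage points lower from compound 1 to compound 3 (within the scatter), which is a small drift rather than a shift beyond the scatter. Compound 3 is estimated to give 84% in this assay, with a range from 62% to 97%.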

Compound 3, a percentage reported as inhibition, at one concentration (the size of the read-out at that concentration, not a potency): 68%
Compound 3: middle estimate off by 16 percentage points, on the high side; the range from low to high includes it.
By their numbers in this assay, from the lowest: compound 3; then compounds 1 and 2 (each within the scatter of the next).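

Among the compounds shown here, this position turns out to matter in a way the earlier compounds could not show: in this assay, fluoro in place of cyano on the aromatic carbon of the sulfonyl-bound ring gives a number 22 percentage points lower from compound 1 to compound 3 (beyond the scatter), the first step here that lies beyond the scatter. For the compounds shown here, the only earlier step, a number 3 percentage points higher from compound 1 to compound 2 (within the scatter), concerned a different part of the molecule, so the read-out is now seen to respond to a change in the 3-cyanophenyl group even though, at this single concentration, compound 3 still gives 68% and so retains a sizeable inhibition. The data show the size of this drop but offer no measurement that explains it.

Going by these compounds alone, with only one exchange at this place, it stays open whether the drop reflects losing the cyano or gaining the fluoro, and whether a plain hydrogen, a methoxy, an amine or a carboxylic acid in the same place would read closer to compound 1 or to compound 3. From the compounds shown here alone, it is also open whether the same exchange would give a step of similar size when made on compound 2, which carries fluoro instead of methoxy on the shared core.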